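The source may report more compounds than this note shows. Statements on the series, on what has been measured and on what is new or still open speak of the compounds shown alone.

Compound 1 `CC(O)(C(=O)Nc1ccc(S(=O)(=O)c2cccc(Cl)c2)cc1)C(F)(F)F` and compound 2 `CC(O)(C(=O)Nc1ccc(S(=O)(=O)c2ccc(Br)cc2)cc1)C(F)(F)F` share one core and differ only in the group on the sulfonyl sulfur. In a functional assay (Cavia porcellus) with sulfonylurea receptors; K-ATP channels (Homo sapiens) as the target (a lower number here means a stronger inhibitor, a higher number a weaker inhibitor), compound 1 gives 10000 nM. Compound 2 reaches only the limit of this assay, > 30000 nM. Among the compounds with values here, the single measured step, an at least 3.0-fold higher number from compound 1 to compound 2 (0.47 log units; beyond the scatter), is shaped by the limit of > 30000 nM in this assay, at which 1 of the 2 values shown sits. Compound 3 `CC(O)(C(=O)Nc1ccc(S(=O)(=O)c2cncs2)cc1)C(F)(F)F` differs from compound 2 by 1,3-thiazol-5-yl in place of 4-bromophenyl on a sulfonyl sulfur. Within the data shown here, no measured step covers this change, and with compound 2 at a limit the step cannot be sized from the data. Compound 3 is nonetheless expected to remain a weak inhibitor, estimated at 20000 nM within 4000 nM to 100000 nM. This expectation corresponds to an at least 1.5-fold lower number from compound 2 to compound 3 (0.17 log units; that floor lies within the scatter).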

Compound 3, half-maximal inhibitory concentration: 7700 nM
The estimate for compound 3 lay 2.6-fold (0.41 log units) above the measured number, within the range that was stated.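

In this assay the change on the sulfonyl sulfur from 4-bromophenyl to 1,3-thiazol-5-yl gives an at least 3.8-fold lower number from compound 2 to compound 3 (0.59 log units; beyond the scatter) and this step has only a floor, since compound 2 stands at a limit: the limit of > 30000 nM in this assay, at which 1 of the 3 values shown sits. Against 3-chlorophenyl the same ring gives a 1.3-fold lower number from compound 1 to compound 3 (0.11 log units; within the scatter) so that compound 1 and compound 3 stand level. A five-membered aromatic ring with 2 hetero atoms therefore matches 3-chlorophenyl at this position. Going by these compounds, what an amine or a carboxylic acid on the sulfonyl sulfur would give stays open. So does the full size of the step from compound 2.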